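Trimming a Chain to Hydrogen in a Receptor Agonist Series

The compounds below may be only part of what the source reports. "The series", "measured", "known", "first", "only" and "open" are said of these compounds alone.

Compound 1 `O=C(CCc1cnc(N2CCC(c3nc(COc4ccc(-n5cnnn5)cc4)cs3)CC2)nc1)NOCc1ccccc1` gives "not determined" (no result reported) in a functional assay on cells for agonist activity at Glucose-dependent insulinotropic receptor (Homo sapiens), read by a luciferase reporter, with a stated time of 6 h; a higher number here means that more compound is needed for the effect, a lower number that less compound is needed; it stands among two compounds without a single number, since compound 3 `CC(C)(O)CN1CCC(c2nc(COc3ccc(/C=C4\CC(=O)NC4=O)cc3F)cs2)CC1` likewise gives "not determined" (no result reported) in this assay. Only compound 2 `CCc1cnc(N2CCC(c3nc(COc4c(F)cc(/C=C5\CC(=O)NC5=O)cc4F)cs3)CC2)nc1` carries a value there, giving 211 nM in this assay. Compound 4 `CCc1cnc(N2CCC(c3nc(COc4ccc(-n5cnnn5)cc4)cs3)CC2)nc1` differs from compound 1 by hydrogen in place of (benzyloxy)carbamoyl on a saturated chain carbon, two bonds along the chain from an aromatic carbon. With no number for compound 1, the direction of this step in this assay cannot be read from the data; a change of this size on a chain is expected to move the half-maximal effective concentration only modestly, plausibly within the scatter of repeated runs. Compound 4 is estimated to give 120 nM, with a likely range from 25 nM to 600 nM.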

Compound 4, half-maximal effective concentration: 87 nM
Compound 4: the middle estimate sits 1.4-fold (0.14 log units) above what was measured, and the stated range covers the measured number.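

Among these compounds, compound 1 has no single number in this assay, so no step to compound 4 can be read. As far as these compounds go, what the (benzyloxy)carbamoyl group does to agonist activity stays open, and no measured evidence bears on it.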